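The source may report more compounds than this note shows. Statements on the series, on what has been measured and on what is new or still open speak of the compounds shown alone.

In an ADME assay on L02 cells (Homo sapiens) for cytotoxicity, read by MTT assay, with a stated time of 72 h (on this read-out lower numbers stand for stronger inhibition and higher numbers for weaker inhibition), compound 1 `C=CC(=O)Nc1cccc(Oc2nc(Nc3ccn(C)n3)nc3c2CSCC3)c1` reports only a limit, > 50000 nM. Among the measured compounds shown here, compound 2 `C=CC(=O)Nc1cccc(Oc2nc(Nc3cccc(OC)c3)nc3c2CSCC3)c1` gives 48900 nM, the only actual number so far. For the measured compounds named here, the one measured step, an at least 1.0-fold lower number from compound 1 to compound 2 (0.00 log units; that floor lies within the scatter), concerns the group on a nitrogen on an aromatic ring. Compound 3 `COc1cccc(Nc2nc3c(c(Oc4cccc(NC(=O)/C=C/C(C)C)c4)n2)CSCC3)c1` differs from compound 2 in another place, on a carbonyl carbon: 3-methylbut-1-en-1-yl in place of vinyl on a carbonyl carbon. Going by the values given here, no measured step covers this change, so an at least 1.0-fold lower number from compound 1 to compound 2 (0.00 log units; that floor lies within the scatter) is only a loose guide, and no shift beyond the scatter is expected. The expected step is a 1.0-fold higher number from compound 2 to compound 3 (0.01 log units; within the scatter). For compound 3 the estimate in this assay is 50000 nM, with an expected range of 20000 nM to 100000 nM.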

Compound 3, half-maximal inhibitory concentration: > 50000 nM
Compound 3 ended at the assay's limit; the forecaster's own chance of this, stated with the estimate: 50%; the middle value sits exactly at the limit.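

The change from vinyl to 3-methylbut-1-en-1-yl on a carbonyl carbon gives, in this assay, an at least 1.0-fold higher number from compound 2 to compound 3 (0.00 log units; that floor lies within the scatter). Compound 3 reports only a limit, > 50000 nM, so this floor is all that can be read of the step. Like the earlier change on a nitrogen on an aromatic ring, this one yields no step that can be told from the scatter, and the results gather at one point: the limit of > 50000 nM in this assay, at which 2 of the 3 values shown sit.

On these data alone, whether a saturated ethyl group or a chain bearing a dimethylamino group on that carbonyl carbon would give a lower number in this assay remains open.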